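A few compounds are considered here, and "the series" means these few. Any claim that something is new, unique, unknown or untested is made for them only; others in the source may bear on it.

The measured compounds, with their results in a functional assay, with a stated time of 30 min (a higher number here means a weaker inhibitor, a lower number a stronger inhibitor), are:
compound 1 `COc1ccc(C2CC(=NOC(=O)c3ccc([N+](=O)[O-])cc3)CC(c3ccc(OC)cc3)N2C)cc1`, 280000 nM;
compound 2 `COc1ccc(C2CC(=NOC(=O)c3cccc(O)c3)CC(c3ccc(OC)cc3)N2C)cc1`, 34000 nM;
compound 3 `COc1ccc(C2CC(=NOC(=O)c3ccc(O)cc3)CC(c3ccc(OC)cc3)N2C)cc1`, 25000 nM.

Compound 3 has the lowest of the three numbers in this assay. The step of a 1.4-fold lower number from compound 2 to compound 3 (0.13 log units; within the scatter) is within the scatter, so compound 2 and compound 3 cannot be told apart on these numbers, whereas an 11-fold lower number from compound 1 to compound 3 (1.05 log units; beyond the scatter) lies beyond it.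

Compound 4 `COc1ccc(C2CC(=NOC(=O)c3cc(O)c(O)c(O)c3)CC(c3ccc(OC)cc3)N2C)cc1` differs from compound 3 by 3,4,5-trihydroxyphenyl in place of 4-hydroxyphenyl on a carbonyl carbon. Two of the measured steps concern a hydroxy group entering in place of a nitro group, an 8.2-fold lower number from compound 1 to compound 2 (0.92 log units; beyond the scatter) and an 11-fold lower number from compound 1 to compound 3 (1.05 log units; beyond the scatter), both well beyond the scatter and lowering the number in this assay. The third, a 1.4-fold lower number from compound 2 to compound 3 (0.13 log units; within the scatter), shows that shifting a single hydroxy group between two places on the ring changes nothing beyond the scatter. Going by the values given here, no measured step adds further hydroxy groups to a ring that already carries one, so there is no direct precedent for this change. With two extra hydroxy groups entering, a modest further lowering is possible, but the more cautious expectation is a step about the size of the scatter.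

Compound 4 is therefore expected to give 15000 nM in this assay, within 4000 nM to 60000 nM, corresponding to an expected step of a 1.7-fold lower number from compound 3 to compound 4 (0.22 log units; within the scatter).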

Compound 4, half-maximal inhibitory concentration: 18000 nM
Estimate against measurement, compound 4: 1.2-fold (0.08 log units) below; low and high end bracket the measured number.
By their numbers in this assay, from the lowest: compounds 4, 3 and 2 (each within the scatter of the next); then compound 1.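

In this assay, 3,4,5-trihydroxyphenyl in place of 4-hydroxyphenyl on the carbonyl carbon gives a 1.4-fold lower number from compound 3 to compound 4 (0.14 log units; within the scatter) and, measured against the other single-hydroxy ring, a 1.9-fold lower number from compound 2 to compound 4 (0.28 log units; within the scatter), so the ring with three hydroxy groups cannot be told apart from either ring with one. The earlier compounds had shown only that moving one hydroxy group around the ring made no difference beyond the scatter; compound 4 extends this to the number of hydroxy groups, at least across these three rings, which the earlier steps could not address. The only separations beyond the scatter still involve the 4-nitrophenyl ring, as a 16-fold lower number from compound 1 to compound 4 (1.19 log units; beyond the scatter) shows, and no evidence is available to explain why the added hydroxy groups leave the number unresolved from those of compound 2 and compound 3.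

The compounds shown leave open whether methoxy groups in place of the three hydroxy groups would behave the same way. They also leave open whether an amine or a carboxylic acid on the ring, or a saturated chain in place of the ring, would move the number beyond the scatter from that of compound 4.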